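This account rests on a few compounds, and the source may have more. Where it says the series, first, only, none or still open, it means among the compounds named here.

Three close analogues built on one shared core have been tested for toxicity toward human erythroleukemia cells, and a fourth is now to follow. In an ADME assay on HEL cells (Homo sapiens) for cytotoxicity, with a stated time of 3 days (on this read-out lower numbers stand for higher toxicity in this test and higher numbers for lower toxicity in this test), compound 1 `CCC1(Cc2ccccc2)OS(=O)(=O)C=C1OCc1ccc(F)cc1` reports only a limit of the assay, >= 50000 nM. Compound 2 `CCC1(Cc2ccccc2)OS(=O)(=O)C=C1OCc1ccc(Cl)cc1` likewise reports a limit in this assay, >= 50000 nM. Compound 3 `CCC1(Cc2ccccc2)OS(=O)(=O)C=C1OCc1cccc(Cl)c1` reports a limit in this assay as well, >= 20000 nM. Compound 2 therefore stands at the limit of >= 50000 nM in this assay, at which 2 of the 3 values shown sit, while the limit of >= 20000 nM in this assay, at which 1 of the 3 values shown sits, is where the third value rests.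

Every measured value is a limit. Going by the values given here, none of the measured steps can therefore be read: a step that the two limits leave unreadable from compound 1 to compound 2, a step that the two limits leave unreadable from compound 1 to compound 3 and a step that the two limits leave unreadable from compound 2 to compound 3 are all left without a size by the limits on either side.

The new member is compound 4 `CCC1(Cc2ccccc2)OS(=O)(=O)C=C1OCc1ccc(C(F)(F)F)cc1`. The change from compound 2 is trifluoromethyl in place of chloro on an aromatic carbon. The steps among the measured compounds, all unreadable, give no sign of any effect of a change on the aromatic ring that this assay can resolve, so no step beyond the scatter in either direction is expected. The step from compound 2 to compound 4 is estimated as a number no higher from compound 2 to compound 4 (the limit leaves the size open). Compound 4 is therefore expected to give about 50000 nM in this assay, with a range from 20000 nM to 100000 nM, most likely again reported only as a limit.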

Compound 4, minimum cytotoxic concentration: >= 16000 nM
Compound 4 ended at the assay's limit; the forecaster's own chance of this, stated with the estimate: 80%; the middle value does not contradict the limit.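

The result for compound 4 is again only a limit of the assay, so its steps from compound 1 and compound 2 cannot be read, and neither can any other step among these compounds. The compounds shown leave open where each one's actual toxicity lies in this assay, and whether any change on the aromatic ring alters it.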